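The compounds below may be only part of what the source reports. "The series", "measured", "known", "first", "only" and "open" are said of these compounds alone.

Among the measured compounds shown here, in an ADME assay on a cell-free system (plasma, Homo sapiens) for metabolic stability, with Plasma (Rattus norvegicus) as the target, read by HPLC, at pH 7.4 (on this read-out higher numbers stand for a longer-lived compound and lower numbers for a shorter-lived compound), compound 1 `CC(=O)Oc1ccccc1C(=O)O[C@H]1CO[C@H]2[C@@H]1OC[C@H]2OC(=O)c1snnc1C` gives 0.0642 h, the highest of the three numbers measured so far. Compound 3 `CC(=O)Oc1ccccc1C(=O)O[C@H]1CO[C@H]2[C@@H]1OC[C@H]2OC(=O)C1CC1` gives 0.0322 h in this assay, and compound 2 `CC(=O)Oc1ccccc1C(=O)O[C@H]1CO[C@H]2[C@@H]1OC[C@H]2OC(=O)c1cccc(O)c1` gives 0.0183 h. Compound 4 `CC(=O)Oc1ccccc1C(=O)O[C@H]1CO[C@H]2[C@@H]1OC[C@H]2OC(=O)c1ccncc1` differs from compound 1 in one place: pyridin-4-yl in place of 4-methyl-1,2,3-thiadiazol-5-yl on a carbonyl carbon. For the measured compounds named here, two measured steps bear on a swap at this carbonyl carbon. Putting 3-hydroxyphenyl in that place gave a 3.5-fold lower number from compound 1 to compound 2 (0.55 log units; beyond the scatter), while putting cyclopropyl there gave a 2.0-fold lower number from compound 1 to compound 3 (0.30 log units; within the scatter), the first beyond the scatter and the second within it. A small fall, at most modest, is therefore expected for compound 4. Compound 4 is expected to give 0.032 h, with a range from 0.013 h to 0.08 h. That estimate corresponds to an expected 2.0-fold lower number from compound 1 to compound 4 (0.30 log units; within the scatter).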

Compound 4, half-life: 0.0617 h
Estimate against measurement, compound 4: 1.9-fold (0.29 log units) below; measured number inside the range.
By their numbers in this assay, from the lowest: compounds 2, 3, 4 and 1 (each within the scatter of the next, the first and the last beyond it).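

At this carbonyl carbon, one aromatic ring can replace another with no readable difference in this assay: pyridin-4-yl in place of 4-methyl-1,2,3-thiadiazol-5-yl gives (a 1.0-fold lower number from compound 1 to compound 4 (0.02 log units; within the scatter)). Having an aromatic ring there does not settle the number, since 3-hydroxyphenyl stands apart (a 3.4-fold higher number from compound 2 to compound 4 (0.53 log units; beyond the scatter)), while pyridin-4-yl and cyclopropyl cannot be told apart (a 1.9-fold higher number from compound 3 to compound 4 (0.28 log units; within the scatter)). No measurement here explains these numbers.

Still open, on these data alone, is how a group carrying an amine or a carboxylic acid, or a longer chain, would behave on this carbonyl carbon.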